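A few compounds are considered here, and "the series" means these few. Any claim that something is new, unique, unknown or untested is made for them only; others in the source may bear on it.

Of the compounds shown here, three from one series have been measured. Compound 1, with the structure `C[C@H](c1ccc(C(=O)NCCC(=O)O)cc1)N1C(=O)C(c2ccccc2F)=N[C@]12CC[C@@H](C(C)(C)C)CC2`, gives 1100 nM in an assay on CHO cells for displacement of a labelled ligand from Glucagon receptor (Homo sapiens), read by scintillation counting, with a stated time of 60 min; on this read-out lower numbers stand for stronger inhibition and higher numbers for weaker inhibition. Compound 2, with the structure `CC(C)(C)[C@H]1CC[C@]2(CC1)N=C(c1ccc(Cl)cc1)C(=O)N2Cc1ccc(C(=O)NCCC(=O)O)cc1`, gives 940 nM in this assay. Compound 3, with the structure `CCC[C@H](c1ccc(C(=O)NCc2nn[nH]n2)cc1)N1C(=O)C(c2cc(Cl)cc(Cl)c2)=N[C@]12CC[C@@H](C(C)(C)C)CC2`, gives 55 nM in this assay; this is the lowest of the three numbers, and both other compounds lie well beyond the scatter above it, so compound 3 stands as the strongest binder of the three.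

Compound 4, with the structure `CC(C)CC[C@H](c1ccc(C(=O)NCc2nn[nH]n2)cc1)N1C(=O)C(c2cc(Cl)cc(Cl)c2)=N[C@]12CC[C@@H](C(C)(C)C)CC2`, has not yet been measured. It differs from compound 3 in one place: isopropyl in place of methyl on a saturated chain carbon, three bonds along the chain from an amide-type nitrogen in a ring and an aromatic carbon. The shared core, the dichlorophenyl group and the tetrazole-bearing amide are unchanged. Within the data shown here, no measured pair in this set shows what such an extension of a saturated chain does, so the expectation rests on compound 3 alone. Compound 4 is expected to stay close to compound 3, with a step of a 1.2-fold lower number from compound 3 to compound 4 (0.09 log units; within the scatter) that is expected to lie within the scatter, giving an estimated 45 nM in this assay, within a range from 15 nM to 150 nM.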

Compound 4, half-maximal inhibitory concentration: 22 nM
The estimate for compound 4 lay 2.0-fold (0.31 log units) above the measured number; the range from low to high includes it.
By their numbers in this assay, from the lowest: compound 4; then compound 3; then compounds 2 and 1 (each within the scatter of the next).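

Among these compounds, replacing the propyl chain of compound 3 with the isopentyl chain of compound 4 gives a 2.5-fold lower number from compound 3 to compound 4 (0.40 log units; beyond the scatter) in this assay and is the first single-place change in this set. It shows that this position accepts a larger, branched carbon group, with a modest gain in binding rather than a loss. The change adds only carbon, with no ring, hydrogen-bond donor, hydrogen-bond acceptor or net charge, so this gain came without adding any of these. No separate measurement accounts for the lower number.

Still open, on these data alone, is whether the branch itself matters, or whether an unbranched longer chain would do the same. Also open, as far as these compounds go, is how this position would respond to a cyclohexyl ring or to an amine at the end of the chain.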